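The compounds below may be only part of what the source reports. "The series", "measured", "known", "first", "only" and "open" are said of these compounds alone.

Values so far in a functional assay on Molt4/C8 cells (Homo sapiens) for inhibition (a lower number here means a stronger inhibitor, a higher number a weaker inhibitor), are these:
- compound 1 `O=C1/C(=C/c2ccccc2Cl)Cc2ccccc21` gives 128000 nM
- compound 2 `O=C1/C(=C/c2ccccc2[N+](=O)[O-])Cc2ccccc21` gives 2540 nM

Compound 2 holds the lower of the two numbers. Among the measured compounds shown here, the only measured step is a 50-fold lower number from compound 1 to compound 2 (1.70 log units; beyond the scatter) and comes with nitro in place of chloro on an aromatic carbon. It is a large step, but it is a single pair and shows no general trend.

Compound 3 `O=C1/C(=C/c2ccccc2Br)Cc2ccccc21` is the next case, with bromo in place of nitro on an aromatic carbon. This change takes away the nitro group of compound 2 and brings back a halogen, so it runs roughly opposite to the measured step. For the measured compounds named here, no pair comparing chloro with bromo has been measured, so the gap between compound 3 and compound 1 remains open. Compound 1 at 128000 nM is still the nearest guide. The expected step is a 35-fold higher number from compound 2 to compound 3 (1.55 log units; beyond the scatter) in this assay and it would be large, towards a higher number. For compound 3 the estimated value is 90000 nM with an expected range from 25000 nM to 300000 nM in this series.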

Compound 3, half-maximal inhibitory concentration: 95400 nM
Compound 3: the middle estimate sits 1.1-fold (0.03 log units) below what was measured; the range from low to high includes it.
By their numbers in this assay, from the lowest: compound 2; then compounds 3 and 1 (each within the scatter of the next).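

In this assay, the nitro group of compound 2 now stands apart from two halogens instead of one, and bromo in place of nitro on an aromatic carbon gives a large step (a 38-fold higher number from compound 2 to compound 3 (1.57 log units; beyond the scatter)). The direct halogen exchange lies within the scatter (a 1.3-fold lower number from compound 1 to compound 3 (0.13 log units; within the scatter)), so chloro and bromo cannot be told apart at this place on the shared core. Across these three compounds, the nitro compound is therefore the only one separated from the rest by a step beyond the scatter, and none of the three goes against that reading. No measurement at hand offers an explanation for the separation between nitro and the two halogens.

Still open, from the compounds shown here alone, is whether the separation is particular to nitro, or whether a nitrile, a carboxylic acid, an amine or a methoxy group at the same place would fall with nitro or with the halogens. Fluoro would test whether the match between chloro and bromo extends to a third halogen.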